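The source may report more compounds than this note shows. Statements on the series, on what has been measured and on what is new or still open speak of the compounds shown alone.

Compound 1 `O=C1/C(=C/c2ccccc2)Cc2cc(O)ccc21` – 1940 nM
Compound 2 `O=C1/C(=C/c2cccc(F)c2)Cc2cc(O)ccc21` – 458 nM
Compound 3 `O=C1/C(=C/c2cccc(Cl)c2)Cc2cc(O)ccc21` – 157 nM

In an assay on isolated protein for inhibition of Amine oxidase [flavin-containing] A (Homo sapiens), read by fluorescence and spectrophotometry, with a stated time of 20 min (a higher number here means a weaker inhibitor, a lower number a stronger inhibitor), compound 3 gives the lowest number of the three. The nearest is compound 2, reached by a 2.9-fold lower number from compound 2 to compound 3 (0.46 log units; beyond the scatter), and the furthest is compound 1, reached by a 12-fold lower number from compound 1 to compound 3 (1.09 log units; beyond the scatter). Compound 4 `Cc1cccc(/C=C2\Cc3cc(O)ccc3C2=O)c1` is not yet measured; it differs from compound 3 by methyl in place of chloro on an aromatic carbon.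

For the measured compounds named here, two measured steps bear on this position. The step of a 12-fold lower number from compound 1 to compound 3 (1.09 log units; beyond the scatter) shows that putting chloro there, in place of hydrogen, lowered the number by a large amount, and the step of a 2.9-fold lower number from compound 2 to compound 3 (0.46 log units; beyond the scatter) shows that chloro did better than fluoro there by a modest amount. Going by the values given here, no measured pair shows methyl at this place, so the size of a methyl-for-chloro swap is uncertain. Since chloro gave the lowest number seen, a modest rise in the number, or no step beyond the scatter, is expected, a 2.0-fold higher number from compound 3 to compound 4 (0.31 log units; beyond the scatter). Compound 4 is therefore estimated at 320 nM, with a range from 120 nM to 850 nM.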

Compound 4, half-maximal inhibitory concentration: 860 nM
The estimate for compound 4 lay 2.7-fold (0.43 log units) below the measured number; measured number outside the range, above it.
By their numbers in this assay, from the lowest: compound 3; then compounds 2 and 4 (each within the scatter of the next); then compound 1.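

In this assay, methyl at this place still gives a lower number than plain hydrogen (a 2.3-fold lower number from compound 1 to compound 4 (0.35 log units; beyond the scatter)), so the gain seen with fluoro and chloro is not limited to halogens. Replacing chloro with methyl gives back much of that gain (a 5.5-fold higher number from compound 3 to compound 4 (0.74 log units; beyond the scatter)), even though the two groups match in the simple count, with one heavy atom each, no ring and no net charge. Methyl and fluoro cannot be told apart here (a 1.9-fold higher number from compound 2 to compound 4 (0.27 log units; within the scatter)), which leaves chloro alone as the best of the groups shown at this place.

Nothing shown gives a reason for this order. On these data alone, it remains open whether bromo, methoxy or trifluoromethyl would match chloro at this place, and whether chloro would do as well elsewhere on this ring.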